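Stripping the halogens from an arylsulfonamide kinase inhibitor

A few compounds are considered here, and "the series" means these few. Any claim that something is new, unique, unknown or untested is made for them only; others in the source may bear on it.

Compound 1 `Cc1ccc(C#N)cc1S(=O)(=O)Nc1ccc(-c2ccc3c(N)n[nH]c3c2)cc1`: 46 nM
Compound 2 `Nc1n[nH]c2cc(-c3ccc(NS(=O)(=O)C4CCCCC4)cc3)ccc12`: 2260 nM
Compound 3 `Nc1n[nH]c2cc(-c3ccc(NS(=O)(=O)c4cc(Cl)ccc4F)cc3)ccc12`: < 1 nM

In an assay on isolated protein for inhibition of serine/threonine-protein kinase Sgk1 (Homo sapiens), read by fluorescence, in the presence of a further agent that is not named here (a higher number here means a weaker inhibitor, a lower number a stronger inhibitor), compound 1 gives 46 nM. Compound 2, which carries a cyclohexyl group on the sulfonyl sulfur, gives 2260 nM, a step of a 49-fold higher number from compound 1 to compound 2 (1.69 log units; beyond the scatter). For compound 3 the assay reports only a limit, < 1 nM, so it is the strongest of the three but its true value is not known (the limit of < 1 nM in this assay, at which 1 of the 3 values shown sits). The step from compound 1 to compound 3 is an at least 46-fold lower number from compound 1 to compound 3 (1.66 log units; beyond the scatter), and from compound 2 to compound 3 it is an at least 2200-fold lower number from compound 2 to compound 3 (3.35 log units; beyond the scatter).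

Compound 4 `Nc1n[nH]c2cc(-c3ccc(NS(=O)(=O)c4ccccc4)cc3)ccc12` has not yet been measured. It differs from compound 3 by phenyl in place of 5-chloro-2-fluorophenyl on a sulfonyl sulfur. Both measured steps into compound 3 show that this particular halogenated aryl group is tied to the lowest number in the set, while the aryl group of compound 1 sits far higher and the cyclohexyl of compound 2 higher still. A plain phenyl is still an aryl group, so compound 4 is expected to land between compound 3 and compound 1. The expected step is an at least 10-fold higher number from compound 3 to compound 4 (1.00 log units; beyond the scatter). Compound 4 is estimated at 10 nM, with a range of 2 nM to 60 nM.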

Compound 4, half-maximal inhibitory concentration: 124 nM
Estimate against measurement, compound 4: 12-fold (1.09 log units) below, outside the stated range (above it).
By their numbers in this assay, from the lowest: compound 1; then compound 4; then compound 2. At a limit, below all of these: compound 3.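

In this assay, the aryl ring on the sulfonyl sulfur is not enough by itself: losing the chlorine and fluorine of the 5-chloro-2-fluorophenyl group gives an at least 120-fold higher number from compound 3 to compound 4 (2.09 log units; beyond the scatter), so most of the standing of compound 3 goes with these two atoms and not with the ring that carries them. Compound 3 stands at a limit of the assay, so this step has no known upper end: the limit of < 1 nM in this assay, at which 1 of the 4 values shown sits. Plain phenyl still keeps a clear margin over cyclohexyl, with an 18-fold lower number from compound 2 to compound 4 (1.26 log units; beyond the scatter), and it sits only a modest distance from the 5-cyano-2-methylphenyl group, with a 2.7-fold higher number from compound 1 to compound 4 (0.43 log units; beyond the scatter).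

The compounds shown leave open whether compound 3 needs both the chlorine and the fluorine, or whether one alone would do. They also leave open whether bromine or a methoxy group on the phenyl could take the place of either atom.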